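A few compounds are considered here, and "the series" means these few. Any claim that something is new, unique, unknown or untested is made for them only; others in the source may bear on it.

Measured compounds:
compound 1 `c1ccc(NC2=NCCC3(CCCCC3)S2)cc1` gives 1.81 10^-6 cm/s in a physicochemical assay for permeability; on this read-out higher numbers stand for higher permeability and lower numbers for lower permeability;
compound 2 `CC(=O)c1cccc(NC2=NCCC3(CCCCC3)S2)c1` gives 74.7 10^-6 cm/s in this assay.

Compound 1 stands lowest of the two numbers, its nearest neighbour being compound 2. Compound 3 `CC(=O)c1ccc(NC2=NCCC3(CCCCC3)S2)cc1` differs from compound 1 by acetyl in place of hydrogen on an aromatic carbon. For the measured compounds named here, the one measured step that bears on this change, a 41-fold higher number from compound 1 to compound 2 (1.62 log units; beyond the scatter), was large. An increase of similar size is therefore expected for compound 3 in this assay, namely a 28-fold higher number from compound 1 to compound 3 (1.44 log units; beyond the scatter), with the usual scatter leaving the exact figure open. Compound 3 is estimated at 50 10^-6 cm/s, within a range from 15 10^-6 cm/s to 150 10^-6 cm/s.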

Compound 3, apparent permeability: 2.55 10^-6 cm/s
The estimate for compound 3 lay 20-fold (1.29 log units) above the measured number, outside the stated range (below it).
By their numbers in this assay, from the lowest: compounds 1 and 3 (each within the scatter of the next); then compound 2.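

In this assay, acetyl in place of hydrogen on an aromatic carbon, para to a large group, gives a 1.4-fold higher number from compound 1 to compound 3 (0.15 log units; within the scatter) while the same group at the ring position it holds in compound 2 gives a 41-fold higher number from compound 1 to compound 2 (1.62 log units; beyond the scatter) on the same read-out. The outcome of this change thus depends on where the acetyl stands on the ring, and the large step does not carry over to this position. Nothing available explains the difference.

On these data alone, whether an amine or a carboxylic acid at this position would stay as close to compound 1 remains open.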